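Cyanobenzyl for thienylmethyl on a core that never fires

The source may hold more compounds than are shown below. What is called first, only, known or untested is meant among the compounds shown, and "the series" means these compounds.

Compound 3 `Cc1cc(Cc2ccsc2)c(=O)n(CC(=O)Nc2ccc(Br)cc2)n1` belongs to a small set sharing one core with compound 1 `COc1cccc(Cc2cc(-c3ccc(C)cc3)nn(CC(=O)Nc3ccc(F)cc3)c2=O)c1` and compound 2 `Cc1cc(Cc2cccc(Br)c2)c(=O)n(CC(=O)Nc2ccc(Br)cc2)n1`. In an assay on HL-60 cells for agonist activity at N-formyl peptide receptor 3 (Homo sapiens), read by calcium flux (a higher number here means that more compound is needed for the effect, a lower number that less compound is needed), compound 3 gives only a limit, > 50000 nM. In this assay compound 1 likewise gives only a limit, > 50000 nM. Compound 2 also gives only a limit in this assay, > 50000 nM. Compound 3 therefore stands exactly where every measured member of the set stands, at the limit of > 50000 nM in this assay, at which 3 of the 3 values shown sit, with no number that would separate it from the others.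

Compound 4 `Cc1cc(Cc2ccc(C#N)cc2)c(=O)n(CC(=O)Nc2ccc(Br)cc2)n1` is the unmeasured follow-up; its difference from compound 3 is 4-cyanophenyl in place of thiophen-3-yl on a saturated chain carbon bound to an aromatic carbon. Going by the values given here, the one measured step at the same place on the molecule, a step that the two limits leave unreadable from compound 2 to compound 3, runs between two limits and carries no readable size. No other measured step touches this change, and nothing among the shown values distinguishes one aryl group on that chain carbon from another.

The step in this assay is therefore expected to be a step that the limit leaves unreadable from compound 3 to compound 4, which is to say no movement the assay could resolve. Compound 4 is thus estimated at 60000 nM in this assay, with a range of 15000 nM to 250000 nM, and it is expected most likely to return only the limit again rather than a number.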

Compound 4, half-maximal effective concentration: > 50000 nM
Compound 4 ended at the assay's limit (the forecaster's own chance of this, stated with the estimate: 85%); the middle value lies beyond the limit too.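

Compound 4 also gives only a limit in this assay, so its steps from compound 2 and from compound 3 run between limits and cannot be read: the limit of > 50000 nM in this assay, at which 4 of the 4 values shown sit.

The compounds shown leave open whether any group on that saturated chain carbon, or any change elsewhere on the shared core, would give a readable value in this assay.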